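Compound 4: 3,4-dichlorophenyl replacing 3-(trifluoromethyl)phenyl

The source may hold more compounds than are shown below. What is called first, only, known or untested is meant among the compounds shown, and "the series" means these compounds.

Of the compounds shown here, three have numbers so far in a functional assay on OVCAR-4 cells (Homo sapiens) for inhibition, read by sulforhodamine B assay, with a stated time of 48 h; a lower number here means a stronger inhibitor of growth, a higher number a weaker inhibitor of growth. Compound 1 (`O=C(Nc1cccc(-n2cc(-c3ccncc3)c(-c3ccc(Cl)c(O)c3)n2)c1)Nc1cccc(C(F)(F)F)c1`) gives 3180 nM. Compound 3 (`COc1cc(-c2nn(-c3cccc(NC(=O)c4cccc(C(F)(F)F)c4)c3)cc2-c2ccncc2)ccc1Cl`) gives 2280 nM, within the scatter of compound 1, so these two cannot be ordered. Compound 2 (`COc1cc(-c2nn(-c3cccc(NC(=O)Nc4cc(C(F)(F)F)cc(C(F)(F)F)c4)c3)cc2-c2ccncc2)ccc1Cl`) gives 1120 nM, lower than compound 1 by more than the scatter. Compound 1 therefore sits at the upper end of this small set, alongside compound 3. Among the measured compounds shown here, no two of the three differ in one place only, so no measured step isolates a single change.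

Compound 4 (`O=C(Nc1cccc(-n2cc(-c3ccncc3)c(-c3ccc(Cl)c(O)c3)n2)c1)Nc1ccc(Cl)c(Cl)c1`) keeps the core of compound 1 and has 3,4-dichlorophenyl in place of 3-(trifluoromethyl)phenyl on an amide-type nitrogen. For the measured compounds named here, no measured pair tests this exchange. The expectation rests only on the modest spread of the series, which runs from compound 2 at 1120 nM to compound 1 at 3180 nM. A small step towards a lower number is expected, with nothing beyond the scatter. The expected change is a 1.4-fold lower number from compound 1 to compound 4 (0.16 log units; within the scatter). Compound 4 is estimated at 2200 nM, with an expected range of 900 nM to 5000 nM.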

Compound 4, concentration for 50% growth inhibition: 1690 nM
Compound 4: the middle estimate sits 1.3-fold (0.11 log units) above what was measured; the range from low to high includes it.
By their numbers in this assay, from the lowest: compounds 2, 4, 3 and 1 (each within the scatter of the next, the first and the last beyond it).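

Among the compounds shown here, on the amide-type nitrogen, this is the first exchange that changes one place only: in this assay, 3,4-dichlorophenyl in place of 3-(trifluoromethyl)phenyl gives a 1.9-fold lower number from compound 1 to compound 4 (0.27 log units; within the scatter), so compound 1 and compound 4 cannot be ordered. For the compounds shown here, the position therefore accepts two chlorines on the phenyl ring instead of a trifluoromethyl group, a swap from 10 heavy atoms to 8, with no step that stands clear of the scatter on the core of compound 1. No measurement at hand bears on why the two groups read alike, so this step stays a plain observation without a cause.

The compounds shown leave open whether this nitrogen needs an aromatic ring at all, or whether a cyclohexyl ring, a longer alkyl chain, or a phenyl ring carrying an amine or a carboxylic acid would hold up in this assay. Going by these compounds alone, also open is whether the same exchange reads alike on the methoxy-bearing core of compound 2, since no pair isolates that case.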